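Swapping the morpholine amide for piperidine

This account rests on a few compounds, and the source may have more. Where it says the series, first, only, none or still open, it means among the compounds named here.

Compound 2 `COc1cc(OC)c(-c2nc3cc(/C=C4\SC(=O)N(CC(=O)N5CCOCC5)C4=O)ccc3[nH]2)cc1OC` gives 510 nM in a functional assay on HeLa cells (Homo sapiens) for inhibition, read by MTT assay, with a stated time of 48 h (on this read-out higher numbers stand for weaker inhibition and lower numbers for stronger inhibition), and stands lowest of the two values measured. Within the data shown here, compound 1 `COc1cc(-c2nc3cc(/C=C4\SC(=O)N(CC(=O)N5CCOCC5)C4=O)ccc3[nH]2)cc(OC)c1OC` gives 16300 nM in this assay; the only measured step, a 32-fold lower number from compound 1 to compound 2 (1.50 log units; beyond the scatter), concerns the trimethoxyphenyl group alone. Compound 3 `COc1cc(OC)c(-c2nc3cc(/C=C4\SC(=O)N(CC(=O)N5CCCCC5)C4=O)ccc3[nH]2)cc1OC` differs from compound 2 by piperidin-1-yl in place of morpholin-4-yl on a carbonyl carbon. Among the measured compounds shown here, no measured step touches this amide, so nothing here predicts a shift beyond the scatter. For compound 3 the expected step is a 1.0-fold lower number from compound 2 to compound 3 (0.01 log units; within the scatter), a value estimated near 500 nM, between 200 nM and 1500 nM.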

Compound 3, half-maximal inhibitory concentration: 6890 nM
Compound 3: the middle estimate sits 14-fold (1.14 log units) below what was measured, and the stated range ends below it.
By their numbers in this assay, from the lowest: compound 2; then compound 3; then compound 1.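

In this assay, piperidin-1-yl in place of morpholin-4-yl gives a 14-fold higher number from compound 2 to compound 3 (1.13 log units; beyond the scatter) and so shows that the amide end of the molecule also affects the read-out, not only the trimethoxyphenyl group. The ring stays six-membered with the same heavy-atom count, yet one oxygen exchanged for carbon, with one hydrogen-bond acceptor fewer by count, is enough for a large step. Nothing available explains this step.

As far as these compounds go, whether a piperazine, with a ring nitrogen in place of that oxygen, would behave like compound 2 or compound 3 remains open. So does whether the same amide change has a similar effect alongside the 3,4,5-trimethoxyphenyl group of compound 1.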